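The compounds below may be only part of what the source reports. "The series", "measured", "known", "first", "only" and "open" are said of these compounds alone.

Of the compounds shown here, three sharing a single core have so far been measured in a functional assay on the whole organism for inhibition, with Mus musculus as the target, at a dose of 30 mg/kg by the oral route; on this read-out lower numbers stand for less inhibition and higher numbers for more inhibition at the one dose given (going by the name of the read-out). Compound 1, `O=C(NCCCOc1ccc2nc(O)ccc2c1)N(C1CC1)[C@@H]1CCCCC[C@H]1O`, gives 44%. Compound 2, `O=C(NCCCOc1ccc2nc(O)ccc2c1)N(C1CCCCCCC1)[C@H]1CCCC[C@@H]1O`, gives 100%. Compound 3, `O=C(NCCCOc1ccc2nc(O)ccc2c1)N(C1CC1)[C@H]1CCCC[C@H]1O`, gives 100%. Among the compounds with values here, the only single-point step among them is a number 56 percentage points higher from compound 1 to compound 3 (beyond the scatter). On these numbers compound 3 stands level with compound 2 at the digits shown, the two together forming the highest pair of the three, while compound 1 sits far lower.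

The next compound, compound 4, `O=C(NCCCOc1ccc2nc(O)ccc2c1)N(C1CC1)[C@H]1CCCC[C@@H]1O`, differs from compound 3 in this way: the two compounds have the same atoms and bonds and differ only in configuration as drawn: 1 of 2 stereo elements differ; a stereocentre at a saturated ring carbon is drawn R in compound 3 and S in compound 4. Within the data shown here, no measured step addresses a change of configuration alone; the one step in hand, from compound 1 to compound 3, concerns ring size on the amide-type nitrogen and is therefore only indirect evidence. Since compound 3 already reads at the top of the scale in this assay, any movement for compound 4 can only be downward or none beyond the scatter, and the latter is treated as more likely. Compound 4 is therefore expected to give 90%, between 60% and 100%, an expected step of a number 10 percentage points lower from compound 3 to compound 4 (within the scatter).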

Compound 4, a percentage reported as inhibition, in the whole organism at one dose (the size of the read-out at that dose, not a potency): 100%
Estimate against measurement, compound 4: 10 percentage points below; measured number inside the range.
By their numbers in this assay, from the lowest: compound 1; then compounds 2, 3 and 4 (each within the scatter of the next).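

Turning a stereocentre at a saturated ring carbon from R to S gives no change at the digits printed from compound 3 to compound 4 (within the scatter) in this assay and this is the first direct reading of configuration alone, the comparison being a clean one: the fact that compounds 3 and 4 differ only in the configuration as drawn. Cyclopropyl in place of cyclooctyl on an amide-type nitrogen gives no change at the digits printed from compound 2 to compound 4 (within the scatter) so that, with the configuration drawn alike, these two groups cannot be told apart in this read-out at this one dose. 2-hydroxycyclohexyl in place of 2-hydroxycycloheptyl on the same nitrogen gives a number 56 percentage points higher from compound 1 to compound 4 (beyond the scatter) so the large ring-size step is now seen with both drawn forms of the 2-hydroxycyclohexyl group, those of compound 3 and compound 4.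

With compound 2, compound 3 and compound 4 all reading the same, and compound 4 at 100%, this single dose leaves any real difference among them unresolved, including whether configuration or the size of the group on the nitrogen matters at all. Also open, going by these compounds, is how the read-out would respond if an amine took the place of the ring hydroxyl, or if a longer chain joined the urea-bearing nitrogen to the shared core.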